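Adding a Phenoxy Group to Compound 1

A few compounds are considered here, and "the series" means these few. Any claim that something is new, unique, unknown or untested is made for them only; others in the source may bear on it.

compound 1 `C1=C(c2cccnc2)CC2CNCC1C2` 0.2 nM
compound 2 `Clc1ccncc1C1=CC2CNCC(C1)C2` 3 nM

Of the compounds shown here, two share a core and have been measured in an in vitro assay on SH-EP1 cells for displacement of a labelled ligand from Neuronal acetylcholine receptor; alpha4/beta2 (Homo sapiens); on this read-out higher numbers stand for weaker inhibition and lower numbers for stronger inhibition. Compound 1 gives 0.2 nM, the lowest of the two numbers; the nearest is compound 2, which gives 3 nM. Among the compounds with values here, the single measured step between them is a 15-fold higher number from compound 1 to compound 2 (1.18 log units; beyond the scatter), a chloro in place of hydrogen on an aromatic carbon.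

Compound 3 `C1=C(c2cncc(Oc3ccccc3)c2)CC2CNCC1C2` is not yet measured. It differs from compound 1 by phenoxy in place of hydrogen on an aromatic carbon. Within the data shown here, the only step that bears on this change is the chloro step above: a small group placed on the same six-membered aromatic ring with 1 nitrogen produced a large weakening. Phenoxy is a much larger group and sits two atoms from the ring nitrogen, so the chloro step is an imperfect guide, but it is the only one available. A weakening is therefore expected, with considerable uncertainty about its size. Compound 3 is expected to give 20 nM, in the range 3 nM to 150 nM, meaning an expected step of a 100-fold higher number from compound 1 to compound 3 (2.00 log units; beyond the scatter).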

Compound 3, inhibition constant: 0.7 nM
Estimate against measurement, compound 3: 29-fold (1.46 log units) above; measured number below the stated range.
By their numbers in this assay, from the lowest: compound 1; then compound 3; then compound 2.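

On an aromatic carbon two atoms from the ring nitrogen, phenoxy in place of hydrogen changes the result only modestly in this assay: a 3.5-fold higher number from compound 1 to compound 3 (0.54 log units; beyond the scatter). A group of 7 heavy atoms, including a six-membered aromatic ring of carbon only, can therefore stand at this place, and compound 3 still gives a low number, 0.7 nM. The chloro change, a 15-fold higher number from compound 1 to compound 2 (1.18 log units; beyond the scatter), is printed as a large step even though it adds a single atom, so among these compounds the bigger group does not bring the bigger step, and the chloro result cannot be carried over to every change on this ring.

Nothing shown here accounts for why the phenoxy step is only modest. Still open, going by these compounds, is how other groups at this same place would behave, such as a methoxy group, an amine, a carboxylic acid or a longer chain joined through the oxygen, and whether a fluoro group on the phenoxy ring would shift the number in either direction.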